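The source may hold more compounds than are shown below. What is called first, only, known or untested is meant among the compounds shown, and "the series" means these compounds.

In a functional assay on NCI-H460 cells (Homo sapiens) for inhibition, read by CCK-8 assay, with a stated time of 72 h, tested at 10 uM (on this read-out lower numbers stand for less inhibition of growth and higher numbers for more inhibition of growth at the one concentration tested), three compounds sharing one core have been measured. Compound 1 (`CN(C)C(=O)c1cc2cnc(Nc3ccc(NC(=O)C4(C(=O)Nc5cccc(F)c5)CC4)cc3)nc2n1C1CCCC1`) gives 98.8%, compound 2 (`CN(C)C(=O)c1cc2cnc(Nc3ccc(NC(=O)C4(C(=O)Nc5cccc(Cl)c5)CC4)cc3)nc2n1C1CCCC1`) gives 101%, and compound 3 (`CN(C)C(=O)c1cc2cnc(Nc3ccc(NC(=O)C4(C(=O)Nc5ccc(Br)cc5)CC4)cc3)nc2n1C1CCCC1`) gives 96.4%. Compound 3 therefore stands within the scatter of both other compounds, and the three values cannot be ranked.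

The next structure is compound 4 (`CN(C)C(=O)c1cc2cnc(Nc3ccc(NC(=O)C4(C(=O)Nc5ccc(Cl)c(C(F)(F)F)c5)CC4)cc3)nc2n1C1CCCC1`), which carries 4-chloro-3-(trifluoromethyl)phenyl in place of 4-bromophenyl on an amide-type nitrogen. Three measured steps change the group at this same end of the molecule. They are a number 2.2 percentage points higher from compound 1 to compound 2 (within the scatter), a number 2.4 percentage points lower from compound 1 to compound 3 (within the scatter) and a number 4.6 percentage points lower from compound 2 to compound 3 (within the scatter). For the measured compounds named here, all three are small, but they offer only limited guidance, since no measured compound carries a trifluoromethyl group. With this uncertainty in mind, no step beyond the scatter is expected in this assay, and a direction can only be tentatively assigned. The step expected is a number 1.4 percentage points lower from compound 3 to compound 4 (within the scatter). For compound 4 the estimated value is 95%, with an expected range from 84% to 103%.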

Compound 4, percent growth inhibition at one concentration: 91.9%
For compound 4 the middle estimate is 3.1 percentage points above the measured one, within the range that was stated.
By their numbers in this assay, from the lowest: compounds 4, 3, 1 and 2 (each within the scatter of the next).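

In this assay, for the compounds shown here, 4-chloro-3-(trifluoromethyl)phenyl on the amide-type nitrogen brings the first trifluoromethyl group to this position, and the steps read a number 4.5 percentage points lower from compound 3 to compound 4 (within the scatter) and a number 9.1 percentage points lower from compound 2 to compound 4 (within the scatter) and also a number 6.9 percentage points lower from compound 1 to compound 4 (within the scatter) so that all of them stay inside the scatter. This position on the amide-type nitrogen therefore accepts a phenyl group carrying both chlorine and trifluoromethyl with no step beyond the scatter, and the four compounds still cannot be ranked at the one concentration tested. Nothing available bears on the reason for these numbers.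

On these data alone, whether an amine or a carboxylic acid on the phenyl group, or a saturated piperidine ring in its place, would give a step beyond the scatter remains open. Also open, as far as these compounds go, is whether the four compounds, which cannot be told apart at this single concentration, would separate at lower concentrations.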